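Compound 4: cyano in place of methyl

The source may hold more compounds than are shown below. What is called first, only, known or untested is meant among the compounds shown, and "the series" means these compounds.

Of the compounds shown here, three on the shared core have been read in an ADME assay on microsomes from liver (Mus musculus) for metabolic stability, read by LC-MS, with NADPH named in the record, with a stated time of 60 min, tested at 1 uM, in the absence of a further agent (a higher number here means that more of the compound is left, a lower number that less of the compound is left), so far. Compound 1 `COc1ccc(-c2c(C)nc3c(N4CC[C@@H](NC(=O)OCc5ccccc5)C4)cc(C)nn23)cc1OC` gives > 95% as a limit of the assay and not a number. Compound 2 `COc1ccc(-c2c(C)nc3c(N4CC[C@@H](NC(=O)Oc5cccc(C)c5)C4)cc(C)nn23)cc1OC` gives > 95% as a limit too. Compound 3 `COc1ccc(-c2c(C)nc3c(N4CC[C@@H](NS(=O)(=O)c5ccc(C)cc5)C4)cc(C)nn23)cc1OC` is the starting point here and gives > 95% as a limit as well. For the measured compounds named here, the series thus stands at the limit of > 95% in this assay, at which 3 of the 3 values shown sit, and no member has a number yet.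

Compound 4 `COc1ccc(-c2c(C)nc3c(N4CC[C@@H](NS(=O)(=O)c5ccc(C#N)cc5)C4)cc(C)nn23)cc1OC` carries cyano in place of methyl on an aromatic carbon, para to a large group (cyano in place of methyl on an aromatic carbon). The change reads as 4-methylphenyl to 4-cyanophenyl within the sulfonyl group.

Going by the values given here, two measured steps bear on this group: a step that the two limits leave unreadable from compound 1 to compound 3 and a step that the two limits leave unreadable from compound 2 to compound 3 and neither gives a size. Among the compounds with values here, no measured compound carries cyano. The expectation therefore rests only on compound 3 with its limit of > 95% as the reference. The expected step is a number no higher from compound 3 to compound 4 (the limit leaves the size open) and it is expected to stay within the scatter in this assay with no firm direction. For compound 4 the estimated value is 95% within an expected range of 82% to 100% and a report as a limit again is the likelier outcome.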

Compound 4, percent of the compound remaining: > 95%
Compound 4 gave a limit, no number; the forecaster's own chance of this, stated with the estimate: 65%; the middle value sits exactly at the limit.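

The steps from compound 1, compound 2 and compound 3 to compound 4 cannot be read, as each joins two limits of the assay and not numbers. Whether benzyloxycarbonyl, (3-methylphenoxy)carbonyl, (4-methylphenyl)sulfonyl and (4-cyanophenyl)sulfonyl on the amine nitrogen differ at all in this assay stays open, with no number in the series: the limit of > 95% in this assay, at which 4 of the 4 values shown sit.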